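The compounds below may be only part of what the source reports. "The series", "measured", "known", "first", "only" and "open" are said of these compounds alone.

In a functional assay on MCF7 cells (Homo sapiens) for cytotoxicity, read by MTT assay, with a stated time of 4 h (on this read-out lower numbers stand for stronger inhibition and higher numbers for weaker inhibition), compound 1 `CCC(=O)OC[C@H]1O[C@@H](O[C@@H]2OC=C(C(=O)OC)[C@H]3C[C@H](OC(C)=O)[C@H](C)[C@@H]23)[C@H](OC(C)=O)[C@@H](OC(C)=O)[C@@H]1OC(C)=O` gives 1.88 ug/mL, compound 2 `CCCCCCCCCCCC(=O)OC[C@H]1O[C@@H](O[C@@H]2OC=C(C(=O)OC)[C@H]3C[C@H](OC(C)=O)[C@H](C)[C@@H]23)[C@H](OC(C)=O)[C@@H](OC(C)=O)[C@@H]1OC(C)=O` gives 0.24 ug/mL and compound 3 `CCCCCCCCCCCCCC(=O)OC[C@H]1O[C@@H](O[C@@H]2OC=C(C(=O)OC)[C@H]3C[C@H](OC(C)=O)[C@H](C)[C@@H]23)[C@H](OC(C)=O)[C@@H](OC(C)=O)[C@@H]1OC(C)=O` gives 24.6 ug/mL, the highest of the three numbers. Compound 4 `CCCCCCCCCCCCCCCC(=O)OC[C@H]1O[C@@H](O[C@@H]2OC=C(C(=O)OC)[C@H]3C[C@H](OC(C)=O)[C@H](C)[C@@H]23)[C@H](OC(C)=O)[C@@H](OC(C)=O)[C@@H]1OC(C)=O` differs from compound 3 by ethyl in place of hydrogen on a saturated chain carbon, ten or more bonds along the chain from a carbonyl carbon. The same change has been measured only once, as a 100-fold higher number from compound 2 to compound 3 (2.01 log units; beyond the scatter), a large step upward. The other two steps extend the chain further: a 7.8-fold lower number from compound 1 to compound 2 (0.89 log units; beyond the scatter) runs downward, while a 13-fold higher number from compound 1 to compound 3 (1.12 log units; beyond the scatter) runs upward, so the numbers do not move in one direction along the series. Resting on a 100-fold higher number from compound 2 to compound 3 (2.01 log units; beyond the scatter), a further rise in this assay is expected, though a smaller one, and the estimated step is a 2.4-fold higher number from compound 3 to compound 4 (0.39 log units; beyond the scatter). For compound 4 the estimated value is 60 ug/mL, with an expected range of 12 ug/mL to 250 ug/mL.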

Compound 4, half-maximal inhibitory concentration: "not active" (no number reported)
Compound 4 has no reported number here; there is nothing to compare the estimate with.
By their numbers in this assay, from the lowest: compound 2; then compound 1; then compound 3.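

Among these compounds, compound 4 is reported as "not active" in this assay with no number, so no step from compound 3 to compound 4 can be read. No evidence on hand bears on this result. The compounds shown leave open how the not-active report for compound 4 relates numerically to the value of compound 3.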